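The source may report more compounds than this note shows. Statements on the series, on what has been measured and on what is new or still open speak of the compounds shown alone.

Compound 2 `Cc1ccccc1S(=O)(=O)Nc1ccc(-c2nc3ccccc3o2)cc1` gives 85000 nM in an assay on cells for inhibition of HSP60/HSP10 (Homo sapiens), with a stated time of 60 min (on this read-out higher numbers stand for weaker inhibition and lower numbers for stronger inhibition), the highest of the three numbers here, yet compound 1 `O=S(=O)(Nc1ccc(-c2nc3ccccc3o2)cc1)c1ccccc1C(F)(F)F` with 74000 nM and compound 3 `O=S(=O)(Nc1ccc2oc(-c3ccccc3)nc2c1)c1ccc(F)c(C(F)(F)F)c1` with 69000 nM both lie within the scatter of it, so no order among them can be claimed. Compound 4 `O=S(=O)(Nc1ccc(-c2nc3ccccc3o2)cc1)c1ccc(F)cc1` differs from compound 2 in one place: 4-fluorophenyl in place of 2-methylphenyl on a sulfonyl sulfur. Among the compounds with values here, only one measured step alters the group on the sulfonyl sulfur, a 1.1-fold higher number from compound 1 to compound 2 (0.06 log units; within the scatter), and it stayed within the scatter. Compound 3 is not linked to compound 2 by a single change, and its number is also within the scatter of compound 2. Nothing measured therefore points to a step beyond the scatter in this assay. Compound 4 is expected to give 80000 nM, between 35000 nM and 180000 nM. The expected step is a 1.1-fold lower number from compound 2 to compound 4 (0.03 log units; within the scatter).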

Compound 4, half-maximal inhibitory concentration: 73000 nM
Beside the measured number, compound 4's estimate is 1.1-fold (0.04 log units) above it; measured number inside the range.
By their numbers in this assay, from the lowest: compounds 3, 4, 1 and 2 (each within the scatter of the next).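

Replacing 2-methylphenyl with 4-fluorophenyl on the sulfonyl sulfur gives a 1.2-fold lower number from compound 2 to compound 4 (0.07 log units; within the scatter) in this assay and so stays within the scatter. Alongside a 1.1-fold higher number from compound 1 to compound 2 (0.06 log units; within the scatter) in the same assay, this is a second step at this position that stays within the scatter, and it changes the substituted phenyl group more broadly than the earlier swap of trifluoromethyl for methyl. No measured evidence explains this lack of a clear difference. On these data alone, whether a group of another kind on the sulfonyl sulfur, such as an amine, a carboxylic acid or a longer chain, would give a step beyond the scatter remains open.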